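Ester substituent change in the vinyl sulfonamide series

The source may report more compounds than this note shows. Statements on the series, on what has been measured and on what is new or still open speak of the compounds shown alone.

Compound 1 `C=CS(=O)(=O)NC/C=C/c1cc(OC)cc(O)c1C(=O)OCC1CCCCC1` carries a cyclohexyl group on the ester side; in a functional assay on MV4-11 cells (Homo sapiens) for inhibition, read by luminescence, with a stated time of 72 h, tested at 5 uM (a lower number here means less inhibition of growth, a higher number more inhibition of growth at the concentration tested), compound 1 gives 56.4%, the lowest of the three numbers recorded. Compound 3 `C=CS(=O)(=O)NC/C=C/c1cc(OC)cc(O)c1C(=O)OCc1ccc(F)cc1` gives 70.5% and compound 2 `CCN(CC)C/C=C/C(=O)NC/C=C/c1cc(OCCc2ccc(F)cc2)cc(O)c1C(=O)OC(C)C` gives 84.9%. The measured step of a number 14.1 percentage points higher from compound 1 to compound 3 (beyond the scatter) bears directly on the change at hand. Compound 4 `C=CS(=O)(=O)NC/C=C/c1cc(OC)cc(O)c1C(=O)OCC(C)c1ccccc1` differs from compound 1 as follows: 1-phenylethyl in place of cyclohexyl on a saturated chain carbon bound to an oxygen next to a carbonyl group. Both changes replace the saturated ring with an aromatic one at the same place, so a modest rise of similar size is expected, though the added branching makes the transfer uncertain. For compound 4 the expected step is a number 8.6 percentage points higher from compound 1 to compound 4 (within the scatter). The estimate for compound 4 is 65%, within a range of 50% to 80%.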

Compound 4, percent growth inhibition at one concentration: 9.6%
Compound 4: middle estimate off by 55.4 percentage points, on the high side, outside the stated range (below it).
By their numbers in this assay, from the lowest: compound 4; then compound 1; then compound 3; then compound 2.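

At this place, on a saturated chain carbon bound to an oxygen next to a carbonyl group, an aromatic ring alone does not secure growth inhibition in this assay at all. 1-Phenylethyl gives a number 46.8 percentage points lower from compound 1 to compound 4 (beyond the scatter) and also a number 60.9 percentage points lower from compound 3 to compound 4 (beyond the scatter) so the gain seen with 4-fluorophenyl does not carry over to another aromatic group. Nothing available explains this drop.

As far as these compounds go, whether the loss follows the branching, the spacing of the ring or the absent fluorine remains open. From the compounds shown here alone, how an amine or a carboxylic acid would read at this place is also open.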